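This account rests on a few compounds, and the source may have more. Where it says the series, first, only, none or still open, it means among the compounds named here.

Working notes on the series.

Compound 3 `CCCCCCCCCCCC(=O)OC[C@H](CSC[C@@H](N)C(=O)NCCOCCOCCOCCC(=O)O)OC(=O)CCCCCCCCCCC` stands second highest of the three numbers in an assay on HEK293 cells for agonist activity at Toll-like receptor 2 (Homo sapiens); on this read-out higher numbers stand for an effect only at larger amounts of compound and lower numbers for an effect already at smaller amounts: compound 3 gives 900 nM, whereas compound 1 `CCCCCCCCCCCC(=O)OC[C@H](CSC[C@@H](N)C(=O)NCCCC(C)(C)CO)OC(=O)CCCCCCCCCCC` gives 30700 nM and compound 2 `CCCCCCCCCCCC(=O)OC[C@H](CSC[C@@H](N)C(=O)NCCOCCOS(=O)(=O)O)OC(=O)CCCCCCCCCCC` gives 61 nM. The two steps that reach compound 3 are both large: a 34-fold lower number from compound 1 to compound 3 (1.53 log units; beyond the scatter) and a 15-fold higher number from compound 2 to compound 3 (1.17 log units; beyond the scatter). The first of these shows what the terminal carboxylic acid on an ether-linked chain brings relative to the neutral hydroxyl group; the second shows that the sulfo group gives a lower number than that acid.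

Compound 4 `CCCCCCCCCCCC(=O)OC[C@H](CSC[C@@H](N)C(=O)NCCCCCCCCCC(=O)O)OC(=O)CCCCCCCCCCC` keeps the acid but changes the linker: 7-carboxyheptyl in place of 2-(2-(2-carboxyethoxy)ethoxy)ethoxy on a saturated chain carbon, two bonds along the chain from an amide-type nitrogen. Within the data shown here, no measured step in this assay compares an ether-containing chain with a plain saturated chain carrying the same end group, so the measured steps bear on the acid itself rather than on this linker swap. The acid head is retained and the chain length is comparable, so in this assay the step of a 1.3-fold lower number from compound 3 to compound 4 (0.11 log units; within the scatter) is expected to be small, likely within the scatter. Compound 4 is therefore estimated at 700 nM, with a range from 150 nM to 3000 nM.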

Compound 4, half-maximal effective concentration: 4400 nM
Beside the measured number, compound 4's estimate is 6.3-fold (0.80 log units) below it, and the stated range ends below it.
By their numbers in this assay, from the lowest: compound 2; then compound 3; then compound 4; then compound 1.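

In this assay, the linker at this position matters even with the terminal acid retained: placing 7-carboxyheptyl on the saturated chain carbon in place of 2-(2-(2-carboxyethoxy)ethoxy)ethoxy gives a 4.9-fold higher number from compound 3 to compound 4 (0.69 log units; beyond the scatter). The plain saturated acid chain still gives a lower number than the hydroxyl-ended chain, with a 7.0-fold lower number from compound 1 to compound 4 (0.84 log units; beyond the scatter), but remains well short of the sulfooxy compound, with a 72-fold higher number from compound 2 to compound 4 (1.86 log units; beyond the scatter), so the acid end alone does not fix the read-out. No measurement available here accounts for these steps.

The shown compounds leave open how a sulfooxy end would behave on a plain saturated chain like that of compound 4, since compound 2 differs from compound 4 in both chain and end group. On these data alone, the effect of a phosphate or an amine at the chain end also remains open.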